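The compounds below may be only part of what the source reports. "The series", "measured", "known", "first", "only" and "open" are said of these compounds alone.

In a functional assay on M4E cells (Homo sapiens) for cytotoxicity, read by resazurin assay, with a stated time of 72 h (on this read-out lower numbers stand for stronger inhibition and higher numbers for weaker inhibition), three compounds have been measured. Compound 1 `O=C(/C=C/c1ccc(OCCCCCCO[N+](=O)[O-])c(O)c1)OCCCCCCO[N+](=O)[O-]` reaches only a limit, > 50000 nM, the ceiling of the assay rather than a measured number; it stands at the limit of > 50000 nM in this assay, at which 1 of the 3 values shown sits. Compound 2 `COc1cc(/C=C/C(=O)OCCCCCO[N+](=O)[O-])ccc1O` gives 21800 nM. Compound 3 `COc1cc(/C=C/C(=O)Oc2cccc(OCc3c(-c4ccccc4)no[n+]3[O-])c2)ccc1O` gives 44600 nM. Compound 4 `COc1cc(/C=C/C(=O)OCCCCCCO[N+](=O)[O-])ccc1OCCCCCCO[N+](=O)[O-]` has not yet been tested; it differs from compound 1 in one place: methyl in place of hydrogen on an oxygen on an aromatic ring. Among the compounds with values here, no step between two measured compounds is available here, so the effect of this change cannot be read from a neighbouring pair. Compound 4 is expected to remain close to the ceiling, with an expected step of a number no higher from compound 1 to compound 4 (the limit leaves the size open) that does not pass beyond the scatter. The estimate for compound 4 is 50000 nM, within 20000 nM to 120000 nM.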

Compound 4, half-maximal inhibitory concentration: > 50000 nM
Compound 4 was reported as a limit (the forecaster's own chance of this, stated with the estimate: 55%); the middle value sits exactly at the limit.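

Compound 1 gives > 50000 nM, a limit. Compound 4 gives > 50000 nM, also a limit, so no step can be read between compound 1 and compound 4. The compounds shown leave open what the change from hydroxy to methoxy does on this read-out.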